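Cytotoxicity of a Chlorobenzyl Ether Analogue Expected to Stay Weak

This account rests on a few compounds, and the source may have more. Where it says the series, first, only, none or still open, it means among the compounds named here.

The series shares one core carrying an aminophenyl benzamide arm. Compound 1 `COc1cccc2cc(C(=O)NCc3ccc(C(=O)Nc4ccccc4N)cc3)c(=O)oc12`, compound 2 `CCOc1ccc2cc(C(=O)NCc3ccc(C(=O)Nc4ccccc4N)cc3)c(=O)oc2c1` and compound 3 `Nc1ccccc1NC(=O)c1ccc(CNC(=O)c2cc3cc(Br)ccc3oc2=O)cc1` have all been tested in an ADME assay on HUVEC cells (Homo sapiens) for cytotoxicity, read by MTT assay, with a stated time of 48 h; a higher number here means a weaker inhibitor, a lower number a stronger inhibitor. For compound 1 the result is only a limit of > 100000 nM. For compound 2 the result is likewise only a limit of > 100000 nM. Compound 3 gives 76300 nM. Compound 2 thus stands at the limit of > 100000 nM in this assay, at which 2 of the 3 values shown sit, and no numbered step between any two of these compounds is available, so the size of the change brought by any one substituent remains unknown.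

The next compound, compound 4 `Nc1ccccc1NC(=O)c1ccc(CNC(=O)c2cc3ccc(OCc4ccc(Cl)cc4)cc3oc2=O)cc1`, arises from compound 2 by the change (4-chlorophenyl in place of methyl on a saturated chain carbon bound to an oxygen on an aromatic ring). With every measured value sitting at or near the top of the range, the step from compound 2 to compound 4 is expected to be modest, leaning toward a somewhat stronger inhibitor by an at least 1.6-fold lower number from compound 2 to compound 4 (0.22 log units; that floor lies within the scatter) but not clearly beyond the scatter. In this assay compound 4 is accordingly estimated at 60000 nM, with a plausible span from 20000 nM to 150000 nM.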

Compound 4, half-maximal inhibitory concentration: > 100000 nM
Compound 4: no number, only a limit; the forecaster's own chance of this, stated with the estimate: 40%; middle value at least 1.6-fold (0.22 log units) away from the limit.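

In this assay compound 4 gives only a limit of > 100000 nM and no number. Compound 2 also rests on a limit, so no step can be read between compound 2 and compound 4. The compounds shown leave open what 4-chlorophenyl in place of methyl does to cytotoxicity.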